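A few compounds are considered here, and "the series" means these few. Any claim that something is new, unique, unknown or untested is made for them only; others in the source may bear on it.

Measured compounds:
- compound 1, `O=C1CCC(c2ccncc2)(C2CCN(Cc3ccc(Br)cc3)CC2)C(=O)N1`: 630 nM
- compound 2, `O=CN1CCCC(c2ccccc2)(C2CCN(Cc3ccc(Br)cc3)CC2)C1`: 150 nM

In a functional assay on CHO cells for antagonist activity at C-X-C chemokine receptor type 3 (Homo sapiens), read by GTPgammaS binding, with a stated time of 30 min (on this read-out lower numbers stand for stronger inhibition and higher numbers for weaker inhibition), compound 2 gives 150 nM and stands lowest of the two numbers, while compound 1 gives 630 nM, a gap beyond the usual scatter. Compound 3, `O=C(N1CCCC(c2ccccc2)(C2CCN(Cc3ccc(Br)cc3)CC2)C1)C(F)(F)F`, differs from compound 2 by one change: trifluoromethyl in place of hydrogen on a carbonyl carbon. Going by the values given here, no pair of measured compounds shows what such an exchange does, so neither its direction nor its size is known from these data. Compound 3 is expected near compound 2, with an estimated step of a 1.3-fold higher number from compound 2 to compound 3 (0.12 log units; within the scatter) that may not exceed the scatter. Compound 3 is estimated at 200 nM, expected to fall between 60 nM and 700 nM.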

Compound 3, half-maximal inhibitory concentration: 690 nM
The estimate for compound 3 lay 3.5-fold (0.54 log units) below the measured number; low and high end bracket the measured number.
By their numbers in this assay, from the lowest: compound 2; then compounds 1 and 3 (each within the scatter of the next).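

In this assay, placing trifluoromethyl instead of hydrogen on the carbonyl carbon gives a 4.6-fold higher number from compound 2 to compound 3 (0.66 log units; beyond the scatter) and so weaker inhibition. This position is therefore sensitive to what it carries, and here formyl serves better than (trifluoromethyl)carbonyl. The data shown offer no measurement that explains this step.

From the compounds shown here alone, whether a methyl group, an amine or a longer chain on that carbonyl carbon would resemble hydrogen or trifluoromethyl stays open. So does whether the carbonyl itself is needed at all.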